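The source may report more compounds than this note shows. Statements on the series, on what has been measured and on what is new or still open speak of the compounds shown alone.

Compound 1 `O=C(N/N=C/c1ccccc1O)c1cc(-c2ccccc2)nn1Cc1ccc(Cl)nc1` is the point of departure. Going by the values given here, in a functional assay on A549 cells (Homo sapiens) for cytotoxicity, read by MTT assay, with a stated time of 96 h (a higher number here means a weaker inhibitor, a lower number a stronger inhibitor), compound 1 gives 5830 nM, the lowest of the two numbers measured so far. Among the compounds with values here, the only other compound measured is compound 2 `O=C(N/N=C/c1ccco1)c1cc(-c2ccccc2)nn1Cc1ccc(Cl)nc1`, which in this assay gives 26100 nM; the change a 4.5-fold higher number from compound 1 to compound 2 (0.65 log units; beyond the scatter) shows what swapping the aryl group on the carbon double-bonded to nitrogen does.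

Compound 3 `O=C(N/N=C/c1ccccc1O)c1cc(-c2ccc(Cl)cc2)nn1Cc1ccc(Cl)nc1` is not yet measured. It differs from compound 1 by chloro in place of hydrogen on an aromatic carbon. Within the data shown here, the single measured step concerns a different part of the molecule, the group on the carbon double-bonded to nitrogen, and nothing in the data touches the phenyl that carries the new chloro group. Among the measured compounds shown here, there is therefore no measured step that bears on this change, and no direction can be read from the data.

For that reason compound 3 is expected to show a 1.2-fold lower number from compound 1 to compound 3 (0.07 log units; within the scatter), a step that stays within the ordinary scatter. The estimate for compound 3 is 5000 nM, with a likely range from 2000 nM to 14000 nM.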

Compound 3, half-maximal inhibitory concentration: 3680 nM
Estimate against measurement, compound 3: 1.4-fold (0.13 log units) above, within the range that was stated.
By their numbers in this assay, from the lowest: compounds 3 and 1 (each within the scatter of the next); then compound 2.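

Going by these compounds alone, the change from phenyl to 4-chlorophenyl is the first one measured at this end of the molecule, away from the group on the carbon double-bonded to nitrogen, and in this assay it gives a 1.6-fold lower number from compound 1 to compound 3 (0.20 log units; within the scatter). So a chloro can take the place of hydrogen on this aromatic carbon, para to a large group, with a step that cannot be told apart from ordinary repeat-to-repeat variation, whereas the furan-2-yl swap elsewhere in the molecule gave a 4.5-fold higher number from compound 1 to compound 2 (0.65 log units; beyond the scatter). Nothing measured here offers an explanation for this result.

A single chloro says little about what other groups would do at this position: a methoxy group, an amine or a carboxylic acid could give a very different number, and the compounds shown do not reach them. From the compounds shown here alone, whether chloro would give a similar result alongside furan-2-yl in place of 2-hydroxyphenyl also stays open: the two changes are seen only one at a time.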